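A Second Chlorine on a Compound at the Limit

The compounds below may be only part of what the source reports. "The series", "measured", "known", "first", "only" and "open" are said of these compounds alone.

Of the compounds shown here, two have been measured so far, compound 1 `O=C(Nc1ccc(Cl)c(Cl)c1)N1CCC(c2ccc3nncn3n2)CC1` and compound 2 `O=C(Nc1ccc(Cl)cc1)N1CCN(c2ccc3nncn3n2)CC1`. In an ADME assay on microsomes from liver (Homo sapiens) for metabolic stability, read by LC-MS, using NADPH, with a stated time of 30 min, tested at 2 uM (a lower number here means that the compound disappears faster, a higher number that the compound lasts longer), compound 1 gives > 0.5 h as a limit of the assay and not a number. In this assay compound 2 gives > 0.5 h as a limit of the assay too. As far as these compounds go, compound 2 thus stands at the limit of > 0.5 h in this assay, at which 2 of the 2 values shown sit, and its exact half-life is unknown.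

The next compound is compound 3 `O=C(Nc1ccc(Cl)c(Cl)c1)N1CCN(c2ccc3nncn3n2)CC1`, which carries chloro in place of hydrogen on an aromatic carbon, ortho to the chloro group already there. This takes 4-chlorophenyl to 3,4-dichlorophenyl: chloro in place of hydrogen on an aromatic carbon. Among the compounds with values here, no measured pair shows what such a change does in this assay and no direction can be argued from the data. The expectation rests on compound 2, whose > 0.5 h is a limit and not a number. The expected change is a step that the limit leaves unreadable from compound 2 to compound 3 and this estimate is of a step no larger than the scatter. For compound 3 the estimated half-life is 0.6 h with an expected range from 0.35 h to 1.2 h and a report as a limit alone is also expected to be likely.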

Compound 3, half-life in the Homo sapiens assay: > 0.5 h
Compound 3: only a limit was reported; the forecaster's own chance of this, stated with the estimate: 75%; the middle value lies beyond the limit too.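

In the Homo sapiens assay compound 3 gives > 0.5 h, a limit of the assay and not a number. Within the data shown here, compound 2 stands at the same limit, so no step from compound 2 to compound 3 can be read. The compounds shown leave open the exact half-life of each one and what the added chloro does to it. In a physicochemical assay for solubility, measured as kinetic solubility, at pH 7.4 (on this read-out higher numbers stand for higher solubility and lower numbers for lower solubility), compound 2 gives 200000 nM and compound 3 gives 1800 nM. Here a step can be read: the physicochemical assay shows a 110-fold lower number from compound 2 to compound 3 (2.05 log units; beyond the scatter).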